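Tetrazole for imidazole on the sulfur of compound 1

This account rests on a few compounds, and the source may have more. Where it says the series, first, only, none or still open, it means among the compounds named here.

Compound 1 `CC(C)[C@H](NC(=O)COc1cccc2ccccc12)C(=O)N[C@@H](CC(=O)O)C(=O)CSc1nccn1C` carries a 1-methyl-1H-imidazol-2-yl on the sulfur. In a functional assay on Jurkat cells (Homo sapiens) for inhibition (a higher number here means a weaker inhibitor, a lower number a stronger inhibitor), compound 1 gives > 200000 nM, which is a limit of the assay and not a number. Compound 2 `CC(C)[C@H](NC(=O)COc1cccc2ccccc12)C(=O)N[C@@H](CC(=O)O)C(=O)CSc1nc(-c2ccccc2)c(-c2ccccc2)[nH]1` is reported in this assay only as a limit, > 200000 nM. Compound 3 `CC(C)[C@H](NC(=O)COc1cccc2ccccc12)C(=O)N[C@@H](CC(=O)O)C(=O)CSC1=NCCS1` likewise shows in this assay a limit, > 200000 nM. Where compound 1 stands is thus fixed only as the limit of > 200000 nM in this assay, at which 3 of the 3 values shown sit. Within the data shown here, the one step measured between these compounds is a step that the two limits leave unreadable from compound 1 to compound 3; with both ends at the limit its size is not readable.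

The change to compound 4 `CC(C)[C@H](NC(=O)COc1cccc2ccccc12)C(=O)N[C@@H](CC(=O)O)C(=O)CSc1nnnn1C` is 1-methyl-1H-tetrazol-5-yl in place of 1-methyl-1H-imidazol-2-yl on a sulfur. Among the measured compounds shown here, no measured step with a readable size bears on it, and every value sits at the limit, so there is no ground to expect anything other than a further limit. Compound 4 is therefore expected in this assay at about 200000 nM, within 50000 nM to 1000000 nM. The step this estimate implies, a number no higher from compound 1 to compound 4 (the limit leaves the size open), is expected to be none beyond the scatter, with the result most likely reported again as a limit.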

Compound 4, half-maximal inhibitory concentration: > 200000 nM
Compound 4 was reported as a limit (the forecaster's own chance of this, stated with the estimate: 85%); the middle value lies on the limit itself.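

Compound 4, like compound 1 and compound 3, is reported only as a limit of the assay and not a number, so neither of its steps to those compounds can be read: the limit of > 200000 nM in this assay, at which 4 of the 4 values shown sit.

The compounds shown leave open whether any group on the sulfur brings the shared core to a readable value in this assay.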